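Removing a Fluorine from a Benzamide Measured against a Deacetylase

The source may report more compounds than this note shows. Statements on the series, on what has been measured and on what is new or still open speak of the compounds shown alone.

Two close relatives of one benzamide core have been measured in an assay on isolated protein for inhibition of protein deacetylase HDAC6 (Homo sapiens), read by fluorescence, tested at 1 uM; a higher number here means more inhibition at the concentration tested (going by the name of the read-out), a lower number less inhibition. Compound 1, with the structure `CC(C)(C(=O)Nc1ccc(C(=O)Nc2ccc(F)cc2N)cc1)c1ccccc1`, gives 4%, the lower of the two numbers. Compound 2, with the structure `CC(C)[C@@H](C(=O)Nc1ccc(C(=O)Nc2ccccc2N)cc1)c1ccccc1`, gives 16%, which stands higher, beyond the usual scatter. The two compounds differ in more than one place, so their gap cannot be tied to any single group.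

Compound 3, with the structure `CC(C)(C(=O)Nc1ccc(C(=O)Nc2ccccc2N)cc1)c1ccccc1`, has not yet been measured. It differs from compound 1 in a single way: hydrogen in place of fluoro on an aromatic carbon. Compound 2 also carries no fluoro at that place and gives 16%, but it differs from compound 3 elsewhere too, so it is only a loose guide.

The step in this assay from compound 1 to compound 3 is expected to be small, most likely a modest rise, and it may well fall within the scatter, as a number 4 percentage points higher from compound 1 to compound 3 (within the scatter). Compound 3 is therefore expected to give about 8%, within a range from 0% to 20%.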

Compound 3, a percentage reported as inhibition, at one concentration (the size of the read-out at that concentration, not a potency): 4%
For compound 3 the middle estimate is 4 percentage points above the measured one; the range from low to high includes it.
By their numbers in this assay, from the lowest: compounds 1 and 3 (each within the scatter of the next); then compound 2.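

Going from 2-amino-4-fluorophenyl to 2-aminophenyl, this assay shows no change at the digits printed from compound 1 to compound 3 (within the scatter), and this is the first pair in the series that differs in one place only. On this aromatic carbon, meta to an amino group, fluoro and hydrogen therefore cannot be told apart in this read-out, with compound 3 at 4%, a number that sits close to no inhibition at all at the single concentration tested. Nothing available explains this lack of a step or says what the fluoro does at this carbon.

With both compounds so low, the pair cannot show whether the same swap would leave a mark on a compound that inhibits more strongly, and a fluoro placed on the core of compound 2 would be one way to read that. From the compounds shown here alone, it also remains open whether a chloro, a methyl or a methoxy group on this same carbon would give a number that differs from these, or whether this position stays just as silent for groups larger than a single fluorine.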